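Sulfonamide aryl variation on the shared core

The source may report more compounds than this note shows. Statements on the series, on what has been measured and on what is new or still open speak of the compounds shown alone.

Measured so far in a functional assay on DU-145 cells (Homo sapiens) for antiproliferative activity, read by MTT assay, with a stated time of 72 h; on this read-out higher numbers stand for weaker inhibition and lower numbers for stronger inhibition:
- compound 1, `COc1cccc(N(C)S(=O)(=O)C2CC3OC2C(c2ccc(NC(=O)CCCCCCC(=O)O)cc2)=C3c2ccc(O)cc2)c1`: 62200 nM
- compound 2, `CN(c1ccccc1Cl)S(=O)(=O)C1CC2OC1C(c1ccc(NC(=O)CCCCCCC(=O)O)cc1)=C2c1ccc(O)cc1`: 73500 nM
- compound 3, `CCN(c1ccc(O)cc1)S(=O)(=O)C1CC2OC1C(c1ccc(NC(=O)CCCCCCC(=O)O)cc1)=C2c1ccc(O)cc1`: only a limit of the assay is given for compound 3, > 100000 nM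

Compound 2 holds the highest of the two numbers shown; its nearest neighbour is compound 1, and the step of a 1.2-fold higher number from compound 1 to compound 2 (0.07 log units; within the scatter) is within the scatter. Compound 3 is known only as a limit (the limit of > 100000 nM in this assay, at which 1 of the 3 values shown sits).

Compound 4, `CCN(c1ccc(Cl)cc1)S(=O)(=O)C1CC2OC1C(c1ccc(NC(=O)CCCCCCC(=O)O)cc1)=C2c1ccc(O)cc1`, differs from compound 2 in one place: (4-chlorophenyl)(ethyl)amino in place of (2-chlorophenyl)(methyl)amino on a sulfonyl sulfur

Among the measured compounds shown here, three measured steps bear on this change of the group on the sulfonyl sulfur. a 1.2-fold higher number from compound 1 to compound 2 (0.07 log units; within the scatter), an at least 1.3-fold higher number from compound 2 to compound 3 (0.13 log units; that floor lies within the scatter) and an at least 1.6-fold higher number from compound 1 to compound 3 (0.20 log units; that floor lies within the scatter) all stay within the scatter, although the last two rest on a limit and give only a floor. Across the three measured compounds, exchanging the aryl and the alkyl on the sulfonamide nitrogen has not moved this assay beyond the scatter in either direction. For compound 4 no step beyond the scatter is therefore expected, so a 1.0-fold higher number from compound 2 to compound 4 (0.01 log units; within the scatter) is estimated as essentially flat. Compound 4 is expected to give 75000 nM, within 35000 nM to 160000 nM, with a real chance that only a limit is reported.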

Compound 4, half-maximal inhibitory concentration: 42100 nM
Estimate against measurement, compound 4: 1.8-fold (0.25 log units) above; measured number inside the range.
By their numbers in this assay, from the lowest: compounds 4, 1 and 2 (each within the scatter of the next). At a limit, above all of these: compound 3.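

In this assay, among the compounds shown here, chloro in place of hydroxy on an aromatic carbon gives the first step that clears the scatter: an at least 2.3-fold lower number from compound 3 to compound 4 (0.37 log units; beyond the scatter). The group on the sulfonamide aryl ring can therefore register in this assay, which the earlier exchanges on the sulfonyl sulfur did not show, but this step gives only a floor, since compound 3 is known only as a limit: the limit of > 100000 nM in this assay, at which 1 of the 4 values shown sits. The (4-chlorophenyl)(ethyl)amino group otherwise stays level with the other two measured groups, with a 1.7-fold lower number from compound 2 to compound 4 (0.24 log units; within the scatter) and a 1.5-fold lower number from compound 1 to compound 4 (0.17 log units; within the scatter), so a chloro group on the ring does not separate compound 4 from compound 1 or compound 2.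

In the step from compound 2, the ethyl and the placement of the chlorine change together, so neither can be read alone, and a (4-chlorophenyl)(methyl)amino group would be needed to part them. As far as these compounds go, it also remains open whether a 4-aminophenyl or 4-methoxyphenyl group on the sulfonamide nitrogen would track with chloro or with hydroxy, and whether a hydroxamic acid in place of the carboxylic acid would shift the whole series.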